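A few compounds are considered here, and "the series" means these few. Any claim that something is new, unique, unknown or untested is made for them only; others in the source may bear on it.

The measured compounds in this study:

- compound 1 `CN(C)CCn1cnnc1-c1cc(Oc2ccc(NC(=O)N/N=C/c3c[nH]c4ccccc34)cc2F)ccn1` gives 790 nM in a functional assay on MKN-45 cells (Homo sapiens) for cytotoxicity, read by MTT assay, with a stated time of 72 h; a lower number here means a stronger inhibitor, a higher number a weaker inhibitor
- compound 2 `COc1ccc(OC)c(/C=N/NC(=O)Nc2ccc(Oc3ccnc(-c4nncn4CCN(C)C)c3)c(F)c2)c1` gives 1510 nM in this assay
- compound 3 `CN(C)CCn1cnnc1-c1cc(Oc2ccc(NC(=O)N/N=C/c3cc(Br)c(O)c(Br)c3)cc2F)ccn1` gives 4320 nM in this assay

All three compounds share one core and differ only in the group attached to the carbon with a double bond to nitrogen. Compound 3 stands highest of the three numbers in this assay: the step of a 2.9-fold higher number from compound 2 to compound 3 (0.46 log units; beyond the scatter) and the step of a 5.5-fold higher number from compound 1 to compound 3 (0.74 log units; beyond the scatter) are both beyond the scatter, whereas the step of a 1.9-fold higher number from compound 1 to compound 2 (0.28 log units; within the scatter) stays within it. So swapping the group at this carbon can move the number by a modest amount, and compound 3 sits at the weak end of what has been seen.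

Compound 4 `CN(C)CCn1cnnc1-c1cc(Oc2ccc(NC(=O)N/N=C/c3ccc(Cl)cc3)cc2F)ccn1` is the next compound, and its change from compound 3 is 4-chlorophenyl in place of 3,5-dibromo-4-hydroxyphenyl on a carbon with a double bond to nitrogen. Among the compounds with values here, no measured step swaps in a group of this kind, so the expectation rests on the two steps that arrive at compound 3 and on the direction of the change away from it. A modest lowering of the number is expected, a 2.4-fold lower number from compound 3 to compound 4 (0.38 log units; beyond the scatter), since a step of that size is what the measured swaps at this carbon have produced. Compound 4 is therefore estimated at 1800 nM, with a range from 600 nM to 5500 nM.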

Compound 4, half-maximal inhibitory concentration: 570 nM
Beside the measured number, compound 4's estimate is 3.2-fold (0.50 log units) above it; the whole stated range lies above it.
By their numbers in this assay, from the lowest: compounds 4, 1 and 2 (each within the scatter of the next, the first and the last beyond it); then compound 3.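

In this assay, the swap to 4-chlorophenyl (a 7.6-fold lower number from compound 3 to compound 4 (0.88 log units; beyond the scatter)) leaves compound 3 as the weakest of the four, with every step to it now beyond the scatter, and it shows that removing the 3,5-dibromo-4-hydroxyphenyl group can lower the number at this carbon by more than the earlier swaps suggested. Compound 4 also improves on the 2,5-dimethoxyphenyl group (a 2.6-fold lower number from compound 2 to compound 4 (0.42 log units; beyond the scatter)) and cannot be told apart from the 1H-indol-3-yl group (a 1.4-fold lower number from compound 1 to compound 4 (0.14 log units; within the scatter)), so among these four compounds, a single ring with one chlorine and no hydrogen-bond donors or acceptors does as well as the fused indole. Nothing measured here explains why these groups differ.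

On these data alone, the step from compound 3 to compound 4 changes the bromines, the hydroxyl and the chlorine all at once, so the share of each in the drop remains unknown. The compounds shown also leave open how an unsubstituted phenyl, a 4-fluorophenyl, or a ring carrying an amine or a carboxylic acid would behave at this carbon.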